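The compounds below may be only part of what the source reports. "The series", "measured", "known", "first", "only" and "open" are said of these compounds alone.

Going by the values given here, in a functional assay on SK-OV-3 cells (Homo sapiens) for inhibition, read by CCK-8 assay, with a stated time of 70 h (a lower number here means a stronger inhibitor, a higher number a weaker inhibitor), compound 1 `c1ccc(COc2ccc(OCCOCCNC3CCCC3)cc2)cc1` gives 24800 nM and is one of only two compounds measured so far. The other is compound 2 `c1ccc(COc2ccc(OCCOCCNc3ccncc3)cc2)cc1` at 20600 nM and these two numbers lie within the usual scatter of each other, so neither can be ranked ahead.

Compound 3 `Nc1ccc(COc2ccc(OCCOCCNC3CCCC3)cc2)cc1` has not yet been measured. It differs from compound 1 by amino in place of hydrogen on an aromatic carbon, para to a large group, which turns benzyl into 4-aminobenzyl. The counted difference is amino in place of hydrogen on an aromatic carbon and the rest of the structure stays the same.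

Among the compounds with values here, the one measured step is a 1.2-fold lower number from compound 1 to compound 2 (0.08 log units; within the scatter) and it bears on this change only loosely. It swaps a group on an amine nitrogen, whereas compound 3 changes at an aromatic carbon. Within the data shown here, no measured step touches that carbon, so the data offer no direction for this change. The expected outcome is no step beyond the scatter, and the estimated step is a 1.4-fold lower number from compound 1 to compound 3 (0.14 log units; within the scatter) with wide uncertainty. The estimate for compound 3 is 18000 nM with an expected range from 6000 nM to 45000 nM in this measurement.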

Compound 3, half-maximal inhibitory concentration: 31700 nM
Compound 3: the middle estimate sits 1.8-fold (0.25 log units) below what was measured; the measured number falls inside the stated range.
By their numbers in this assay, from the lowest: compounds 2, 1 and 3 (each within the scatter of the next).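

Going by these compounds alone, this is the first reading at this position, the aromatic carbon para to a large group, and it comes in this assay: turning benzyl into 4-aminobenzyl gives a 1.3-fold higher number from compound 1 to compound 3 (0.11 log units; within the scatter). The step lies within the scatter, so on this evidence amino and hydrogen at this carbon cannot be told apart, and adding this one nitrogen atom with its hydrogen-bond donor and acceptor leaves no measurable mark on the number. No separate measurement comes with this result that could show what lies behind it or how the compound acts on these cells.

A single substituent at one carbon cannot show whether the position as a whole is indifferent to change, and a hydroxyl, a methoxy, a carboxylic acid or a larger amine such as dimethylamino at this carbon could still move the number beyond the scatter. On these data alone, it also remains open whether amino at this carbon would read the same with pyridin-4-yl in place of cyclopentyl on the amine nitrogen.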